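Swapping an Amide for a Urea: What to Expect of Compound 4

The source may hold more compounds than are shown below. What is called first, only, known or untested is meant among the compounds shown, and "the series" means these compounds.

Measured in a functional assay on M21 cells (Homo sapiens) for antiproliferative activity, read by sulforhodamine B assay, with a stated time of 48 h; a lower number here means a stronger inhibitor, a higher number a weaker inhibitor:
- compound 1 `CC(C)C(=O)Nc1ccc(S(=O)(=O)Oc2ccccc2C(C)C)cc1` gives 11000 nM
- compound 2 `CC(C)C(=O)Nc1ccc(S(=O)(=O)Oc2ccccc2I)cc1` gives 13000 nM
- compound 3 `CC(C)c1ccccc1OS(=O)(=O)c1ccc(NC(=O)CCCCl)cc1` gives 5100 nM

Compound 2 carries the highest number of the three. Against compound 1 the difference is a 1.2-fold higher number from compound 1 to compound 2 (0.07 log units; within the scatter), while compound 3 sits clearly lower, beyond the scatter. Compound 4 `CCCNC(=O)Nc1ccc(S(=O)(=O)Oc2ccccc2I)cc1` arises from compound 2 by the change (propylamino in place of isopropyl on a carbonyl carbon). For the measured compounds named here, two measured steps touch this region: the exchange at the carbonyl carbon, a 2.2-fold lower number from compound 1 to compound 3 (0.33 log units; beyond the scatter), was modest, and the exchange on the aromatic carbon, a 1.2-fold higher number from compound 1 to compound 2 (0.07 log units; within the scatter), was negligible. Neither introduces a nitrogen-bearing group, so no firm guide exists; the expected step is a 1.1-fold lower number from compound 2 to compound 4 (0.03 log units; within the scatter), essentially none beyond the scatter. Compound 4 is therefore estimated at 12000 nM, within 4500 nM to 32000 nM.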

Compound 4, half-maximal inhibitory concentration: 5400 nM
Compound 4: middle estimate off by 2.2-fold (0.35 log units), on the high side; low and high end bracket the measured number.
By their numbers in this assay, from the lowest: compounds 3 and 4 (each within the scatter of the next); then compounds 1 and 2 (each within the scatter of the next).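

Replacing the isopropyl on the carbonyl carbon of compound 2 with propylamino turns the amide into a urea, and in this assay this gives a 2.4-fold lower number from compound 2 to compound 4 (0.38 log units; beyond the scatter). So this position also responds to change when iodo is on the core, and a group carrying a nitrogen and a hydrogen-bond donor costs no activity there. No available evidence explains the step.

On these data alone, whether the nitrogen or the chain drives the step stays open. A methylamino or butylamino group at this carbonyl carbon could help separate the two.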